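Adding a Methoxy to the Core: Expected Cytotoxicity

The source may report more compounds than this note shows. Statements on the series, on what has been measured and on what is new or still open speak of the compounds shown alone.

Of the compounds shown here, three sharing one core have been tested in an ADME assay on MT4 cells (Homo sapiens) for cytotoxicity, read by MTT assay, with a stated time of 4 days; on this read-out higher numbers stand for lower toxicity in this test and lower numbers for higher toxicity in this test. Compound 1 `COc1ccc(-c2cc(=O)c3cc(N)ccc3o2)cc1` gives 241000 nM. Compound 2 `Nc1ccc2oc(-c3ccc(F)cc3)cc(=O)c2c1` gives 264000 nM, and compound 3 `Nc1ccc2oc(-c3ccc(C(F)(F)F)cc3)cc(=O)c2c1` gives 273000 nM. Compound 1 has the lowest of the three numbers, but a 1.1-fold higher number from compound 1 to compound 2 (0.04 log units; within the scatter) and a 1.1-fold higher number from compound 1 to compound 3 (0.05 log units; within the scatter) are both within the scatter, as is a 1.0-fold higher number from compound 2 to compound 3 (0.01 log units; within the scatter), so the three compounds cannot be told apart on this read-out.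

Compound 4 `COc1ccc(-c2oc3ccc(N)cc3c(=O)c2OC)cc1` has not yet been measured. It differs from compound 1 by methoxy in place of hydrogen on an aromatic carbon. Going by the values given here, none of the measured steps touches this place on the core: each exchanged one group for another on an aromatic carbon elsewhere, and each moved the number by less than the scatter. Among the compounds with values here, there is no direct evidence for the present change, and the only guide is that the core with its amino group gave much the same number across the three measured variations. A step no larger than the scatter is therefore expected, namely a 1.0-fold lower number from compound 1 to compound 4 (0.00 log units; within the scatter). Compound 4 is estimated at 240000 nM, with a range from 110000 nM to 500000 nM.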

Compound 4, half-maximal cytotoxic concentration: 200000 nM
Estimate against measurement, compound 4: 1.2-fold (0.08 log units) above; the range from low to high includes it.
By their numbers in this assay, from the lowest: compounds 4, 1, 2 and 3 (each within the scatter of the next).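

Compound 4 is the only compound shown that carries a group at this place on the shared core: a methoxy in place of hydrogen on an aromatic carbon, two atoms from the ring oxygen, ortho to a group of 1 heavy atom and ortho to a group of 8 heavy atoms. In this assay the step is a 1.2-fold lower number from compound 1 to compound 4 (0.08 log units; within the scatter), so compound 4 cannot be told apart from compound 1, and this place on the core accepts a methoxy without any change that can be read on this test. No separate measurement is available that could explain this result.

Going by these compounds alone, a single methoxy is only one example, so it remains open whether a hydroxyl, an amine, a carboxylic acid or a longer chain at this place would also stay within the scatter. On these data alone, it also remains open whether this place would give the same result on the cores of compound 2 and compound 3, which carry fluoro and trifluoromethyl instead of the first methoxy.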